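The source may report more compounds than this note shows. Statements on the series, on what has been measured and on what is new or still open speak of the compounds shown alone.

Measured so far in a functional assay on MCF7 cells (Homo sapiens) for antiproliferative activity, read by MTT assay, with a stated time of 24 h, tested at 50 uM; on this read-out higher numbers stand for a weaker effect at the one concentration tested and lower numbers for a stronger effect:
- compound 1, `OC(CCn1nc2c(Br)c(Br)c(Br)c(Br)c2n1)c1cccc(Br)c1`: 14%
- compound 2, `OC(CCn1nc2c(Br)c(Br)c(Br)c(Br)c2n1)c1ccc(F)cc1`: 16%
- compound 3, `C[C@@H](O)CCn1nc2c(Br)c(Br)c(Br)c(Br)c2n1`: 102%

Compound 3 stands highest of the three, far beyond the scatter from compound 2 and compound 1, which sit close together and both show a strong effect at the concentration tested. Compound 3 therefore shows essentially no effect in this assay.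

Compound 4, `OCC(O)Cn1nc2c(Br)c(Br)c(Br)c(Br)c2n1`, is the next member and differs from compound 3 only on the chain: 1,2-dihydroxyethyl in place of 2-hydroxypropyl on a saturated chain carbon bound to an aromatic nitrogen.

Within the data shown here, the one measured step, a number 2 percentage points higher from compound 1 to compound 2 (within the scatter), exchanges one aryl group for another on the chain and so says nothing directly about the change from compound 3 to compound 4. What the numbers do show is that compound 1 and compound 2, which carry an aryl group on the chain, give strong effects, while compound 3, with a short hydroxyalkyl chain only, gives none. Compound 4 likewise carries no aryl group and stays within the same small polar chain type, so no step beyond the scatter is expected: a number 6 percentage points lower from compound 3 to compound 4 (within the scatter) is the estimated change. Compound 4 is expected at 96%, with a range from 78% to 110%.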

Compound 4, a percentage reported as activity, at one concentration (the size of the read-out at that concentration, not a potency): 98%
Compound 4: middle estimate off by 2 percentage points, on the low side; measured number inside the range.
By their numbers in this assay, from the lowest: compounds 1 and 2 (each within the scatter of the next); then compounds 4 and 3 (each within the scatter of the next).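

In this assay, 1,2-dihydroxyethyl in place of 2-hydroxypropyl on a saturated chain carbon bound to an aromatic nitrogen reads as a number 4 percentage points lower from compound 3 to compound 4 (within the scatter). At this place, then, the read-out does not register the exchange, although the entering group carries 2 hydrogen-bond donors and 2 hydrogen-bond acceptors against 1 of each and lacks the defined stereocentre of the leaving group. No measurement on hand accounts for this flat result.

Open, from the compounds shown here alone, is whether an amine, a carboxylic acid or a longer chain at this place would move the number away from the level shared by compound 3 and compound 4. Also open, going by these compounds, is whether a plain phenyl group on the chain would give a read-out like those of compound 1 and compound 2.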